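Benzoate Esters of Aryl-Methylene Ketones: Nitro for Dichloro

The compounds below may be only part of what the source reports. "The series", "measured", "known", "first", "only" and "open" are said of these compounds alone.

Within the data shown here, the two measured members are compound 1, `CC(=O)OC/C(=C\c1ccccc1[N+](=O)[O-])C(=O)c1ccccc1`, and compound 2, `O=C(OC/C(=C\c1ccc(Cl)cc1Cl)C(=O)c1ccccc1)c1ccccc1`. In a functional assay on SW1573 cells (Homo sapiens) for inhibition, read by sulforhodamine B assay, with a stated time of 48 h (a lower number here means a stronger inhibitor of growth, a higher number a weaker inhibitor of growth), compound 1 gives 18000 nM, while compound 2 gives 3300 nM. Among the measured compounds shown here, compound 2 thus stands at the lower of the two numbers, and the gap to compound 1 lies beyond the scatter; the two compounds differ in more than one place, so no single step connects them and only the two values can be compared.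

Compound 3, `O=C(OC/C(=C\c1ccccc1[N+](=O)[O-])C(=O)c1ccccc1)c1ccccc1`, has not been measured in this assay. It differs from compound 2 in one place: 2-nitrophenyl in place of 2,4-dichlorophenyl on a double-bonded chain carbon bound to a double-bonded chain carbon. Compound 1 carries the same 2-nitrophenyl group and shows the higher number, but it also carries a different ester, so its value cannot be read as the effect of this change alone.

The expectation is a step to a higher number from compound 2 to compound 3, estimated as a 2.7-fold higher number from compound 2 to compound 3 (0.44 log units; beyond the scatter), beyond the scatter but short of the full gap to compound 1. Compound 3 is estimated at 9000 nM, within a range from 3000 nM to 27000 nM.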

Compound 3, concentration for 50% growth inhibition: 4300 nM
Estimate against measurement, compound 3: 2.1-fold (0.32 log units) above, within the range that was stated.
By their numbers in this assay, from the lowest: compounds 2 and 3 (each within the scatter of the next); then compound 1.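

In this assay the replacement of 2,4-dichlorophenyl by 2-nitrophenyl on a double-bonded chain carbon bound to a double-bonded chain carbon gives a 1.3-fold higher number from compound 2 to compound 3 (0.11 log units; within the scatter) and so separates neither aryl group from the other at this place, although the two differ in heavy atoms and hydrogen-bond acceptors. Among these compounds, with 2-nitrophenyl held fixed, phenyl in place of methyl on a carbonyl carbon gives a 4.2-fold lower number from compound 1 to compound 3 (0.62 log units; beyond the scatter) and is thus the one step in this small set that lies beyond the scatter, placing the visible change in the ester rather than the aryl group. Nothing measured bears on why either step has the size it has.

The compounds shown leave open whether the two aryl groups also match when methyl rather than phenyl sits on the carbonyl carbon, and so whether the ester step carries over to the 2,4-dichlorophenyl compounds. They also leave open how far the ester can be varied, for instance with a longer chain in place of methyl or with an amine on the benzoate phenyl ring.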